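From carbamoyl to 4-fluorophenyl on the ethenyl chain

The source may report more compounds than this note shows. Statements on the series, on what has been measured and on what is new or still open speak of the compounds shown alone.

In a functional assay on SEM cells (Homo sapiens) for cytotoxicity, with a stated time of 72 h (a lower number here means that less compound is needed, a higher number that more compound is needed for the effect), compound 1 `C=C[C@@](C)(/C=C/c1ccc(O)c(C=O)c1)CCC=C(C)C` gives 8510 nM as a measured number. Compound 2 `C=C[C@@](C)(/C=C/c1ccc(O)c(/C=C/C(N)=O)c1)CCC=C(C)C` gives > 36600 nM as a limit and not a number. Within the data shown here, only one measured step bears on this chain: an at least 4.3-fold higher number from compound 1 to compound 2 (0.63 log units; beyond the scatter) with its size set by that limit. Compound 3 `C=C[C@@](C)(/C=C/c1ccc(O)c(/C=C/c2ccc(F)cc2)c1)CCC=C(C)C` differs from compound 2 by 4-fluorophenyl in place of carbamoyl on a double-bonded chain carbon bound to a double-bonded chain carbon on the same chain. Among the measured compounds shown here, with compound 1 at 8510 nM as the only measured number, a step of similar size toward a lower number is expected in this assay on thin support. The expected move is an at least 3.0-fold lower number from compound 2 to compound 3 (0.48 log units; beyond the scatter) in size. Compound 3 is estimated at 12000 nM with a range of 3000 nM to 36000 nM for this measurement.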

Compound 3, half-maximal effective concentration: > 36600 nM
Compound 3: a limit, no number; the forecaster's own chance of this, stated with the estimate: 30%; middle value at least 3.0-fold (0.48 log units) from the limit.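

A second, quite different substituent on the ethenyl chain also ends at the limit: in this assay compound 3 gives > 36600 nM, a limit and not a number. The change from formyl on an aromatic carbon to 2-(4-fluorophenyl)ethenyl gives an at least 4.3-fold higher number from compound 1 to compound 3 (0.63 log units; beyond the scatter), so the carbamoyl end group is not needed for this loss. The step between compound 2 and compound 3 cannot be read, and the limit now governs most of the series: the limit of > 36600 nM in this assay, at which 2 of the 3 values shown sit.

Open, on these data alone, is how far compound 2 and compound 3 lie past that limit. Also open, as far as these compounds go, is whether an amine or a carboxylic acid at the end of the ethenyl chain would give a measurable number.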